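Swapping the Amide Substituent: From Compound 1 to Compound 3

This account rests on a few compounds, and the source may have more. Where it says the series, first, only, none or still open, it means among the compounds named here.

Measured so far:
compound 1 `COc1cc(-c2cc(C(=O)O)c3ccccc3n2)ccc1OCC(=O)Nc1ccc(F)cc1`: 1.1
compound 2 `COc1cc(-c2cc(C(=O)O)c3ccccc3n2)ccc1OCC(=O)NCc1cccnc1`: -0.8

In a physicochemical assay for lipophilicity, using the shake flask method, in phosphate buffer, measured as octanol-water partition, at pH 7.4 (on this read-out higher numbers stand for higher lipophilicity and lower numbers for lower lipophilicity), compound 1 gives 1.1, the higher of the two measured numbers, and compound 2 gives -0.8. Among the compounds with values here, the only measured step that bears on the question is a number 1.90 log units lower from compound 1 to compound 2 (beyond the scatter), a large downward step. Compound 3 `COc1cc(-c2cc(C(=O)O)c3ccccc3n2)ccc1OCC(=O)NCc1cccs1` differs from compound 1 by (thiophen-2-yl)methyl in place of 4-fluorophenyl on an amide-type nitrogen. The earlier step involved a different entering ring, so only part of that drop is expected here, a moderate step downward, a number 0.40 log units lower from compound 1 to compound 3 (beyond the scatter). Compound 3 is therefore expected to give 0.7, with a range from 0.1 to 1.3.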

Compound 3, distribution coefficient: 0
Estimate against measurement, compound 3: 0.70 log units above, and the stated range ends above it.
By their numbers in this assay, from the lowest: compound 2; then compound 3; then compound 1.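

In this assay the fall at this amide-type nitrogen is not confined to the pyridin-3-yl ring, since (thiophen-2-yl)methyl also gives a number 1.10 log units lower from compound 1 to compound 3 (beyond the scatter) when it replaces 4-fluorophenyl. The entering ring still matters, as thiophen-2-yl in place of pyridin-3-yl on the same saturated chain carbon gives a number 0.80 log units higher from compound 2 to compound 3 (beyond the scatter) and so recovers part of the fall. Nothing given here explains either step.

The compounds shown leave open how much of the fall goes with the added chain carbon and how much with the change of ring. A (4-fluorophenyl)methyl group on this nitrogen would separate the two.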